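From a trifluoromethyl limit to a 4-bromophenyl group

The source may hold more compounds than are shown below. What is called first, only, known or untested is meant among the compounds shown, and "the series" means these compounds.

Compound 1 `COc1ccc(CN(C(=O)CSc2nc3ccccc3s2)c2cc(OC)c(OC)c(OC)c2)cc1N=[N+]=[N-]` gives 2860 nM
Compound 2 `COc1cc(N(Cc2ccccc2)C(=O)CSc2nc3ccccc3s2)cc(OC)c1OC` gives 54500 nM
Compound 3 `COc1ccc(CN(C(=O)CSc2nc3ccccc3s2)c2cc(OC)c(OC)c(OC)c2)cc1C(F)(F)F` gives > 80000 nM as a limit, not a number

In a functional assay on HCT-116 cells (Homo sapiens) for antiproliferative activity, read by MTT assay, with a stated time of 48 h (on this read-out higher numbers stand for weaker inhibition and lower numbers for stronger inhibition), compound 3 yields only a limit (the limit of > 80000 nM in this assay, at which 1 of the 3 values shown sits). Compound 4 `COc1cc(N(Cc2ccc(Br)cc2)C(=O)CSc2nc3ccccc3s2)cc(OC)c1OC` differs from it in one place (4-bromophenyl in place of 4-methoxy-3-(trifluoromethyl)phenyl on a saturated chain carbon bound to an amide-type nitrogen). Two measured steps are large (a 19-fold higher number from compound 1 to compound 2 (1.28 log units; beyond the scatter) and an at least 27-fold higher number from compound 1 to compound 3 (1.44 log units; beyond the scatter)), and both lose the azido group of compound 1. The third (an at least 1.4-fold higher number from compound 2 to compound 3 (0.16 log units; that floor lies within the scatter)) has a floor within the scatter. Compound 4 has no azido group either, so like compound 2 (54500 nM) it is expected to give a high number. A small step toward a lower number, or none beyond the scatter, is expected in this assay (an at least 1.6-fold lower number from compound 3 to compound 4 (0.20 log units; that floor lies within the scatter)). Compound 4 is estimated at 50000 nM with 15000 nM to 100000 nM as its expected range.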

Compound 4, half-maximal inhibitory concentration: 63800 nM
Beside the measured number, compound 4's estimate is 1.3-fold (0.11 log units) below it, and the stated range covers the measured number.
By their numbers in this assay, from the lowest: compound 1; then compounds 2 and 4 (each within the scatter of the next). At a limit, above all of these: compound 3.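

In this assay, bromo in place of hydrogen on an aromatic carbon gives a 1.2-fold higher number from compound 2 to compound 4 (0.07 log units; within the scatter), so the values of compound 2 and compound 4 lie within the scatter of each other. Replacing the azido-bearing group with 4-bromophenyl gives a 22-fold higher number from compound 1 to compound 4 (1.35 log units; beyond the scatter), so compound 4 joins compounds 2 and 3 in lacking azido and standing far weaker than compound 1. 4-bromophenyl in place of 4-methoxy-3-(trifluoromethyl)phenyl on a saturated chain carbon bound to an amide-type nitrogen gives an at least 1.2-fold lower number from compound 3 to compound 4 (0.09 log units; that floor lies within the scatter). Compound 3 stands only at a limit: the limit of > 80000 nM in this assay, at which 1 of the 4 values shown sits.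

As far as these compounds go, whether an amine or a carboxylic acid in place of bromo would come close to compound 1 remains open.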